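A few compounds are considered here, and "the series" means these few. Any claim that something is new, unique, unknown or untested is made for them only; others in the source may bear on it.

Among the compounds with values here, in a functional assay on HEK293 cells for agonist activity at probable G-protein coupled receptor 27 (Homo sapiens), read by a luciferase reporter and beta-arrestin recruitment, with a stated time of 10 min (on this read-out lower numbers stand for an effect already at smaller amounts and higher numbers for an effect only at larger amounts of compound), compound 2 `O=C(Nc1ccc(S(=O)(=O)Nc2ccccc2)cc1)c1ccc(Cl)cc1Br` gives 1020 nM, the only numeric value among the two measured compounds. Compound 1 `O=C(Nc1ccc(Cl)cc1Cl)c1ccc(S(=O)(=O)Nc2ccccc2)cc1` reaches only the limit of the assay, at > 100000 nM, and no number. Compound 3 `N#Cc1ccc(C(=O)Nc2ccc(S(=O)(=O)Nc3ccccc3)cc2)c(F)c1` is the untested analogue that differs from compound 2 by 4-cyano-2-fluorophenyl in place of 2-bromo-4-chlorophenyl on a carbonyl carbon. Within the data shown here, with no measured step available to guide the change, the expectation for compound 3 in this assay rests on the single value of compound 2 alone. Compound 3 is estimated to give 3500 nM, within a range from 600 nM to 30000 nM, and the estimate for the step of a 3.4-fold higher number from compound 2 to compound 3 (0.54 log units; beyond the scatter) is a loss beyond the usual scatter.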

Compound 3, half-maximal effective concentration: 229 nM
Compound 3: the middle estimate sits 15-fold (1.18 log units) above what was measured; the measured number lies below the stated range.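

In this assay, within the data shown here, the step of a 4.5-fold lower number from compound 2 to compound 3 (0.65 log units; beyond the scatter) is the first measured change at this position on the carbonyl carbon, and it shows that the position responds to the ring placed there. It also shows that neither bromine nor chlorine is required, since 4-cyano-2-fluorophenyl carries neither. Nothing shown accounts for the size of this step.

On these data alone, the nitrile and the fluorine enter together, so their separate shares remain open. Also open, as far as these compounds go, is whether a carboxylic acid or a primary amide in place of the nitrile would serve equally well.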